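This account rests on a few compounds, and the source may have more. Where it says the series, first, only, none or still open, it means among the compounds named here.

The measured compounds are compound 1 `O=C(N/N=C/c1ccccc1)c1cnccn1` with 75% in an ADME assay on J774 cells (Mus musculus) for cytotoxicity, read by MTT assay, with a stated time of 48 h, tested at 100 ug/mL (a higher number here means a weaker effect of the compound at the concentration tested, a lower number a stronger effect), compound 2 `O=C(N/N=C/c1cccc(Cl)c1)c1cnccn1` with 100%, and compound 3 `O=C(N/N=C/c1cccc(F)c1)c1cnccn1` with 46%.

Compound 1 stands second highest of the three numbers: compound 2 lies a number 25 percentage points higher from compound 1 to compound 2 (beyond the scatter) from it, while compound 3 lies a number 29 percentage points lower from compound 1 to compound 3 (beyond the scatter); the gap between those two is a number 54 percentage points lower from compound 2 to compound 3 (beyond the scatter).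

Compound 4 `O=C(N/N=C/c1ccccc1Br)c1cnccn1` differs from compound 1 by bromo in place of hydrogen on an aromatic carbon. Both earlier halogen steps from compound 1 bear on this change, and they point in opposite directions. The chloro step a number 25 percentage points higher from compound 1 to compound 2 (beyond the scatter) is the closer guide, though the fluoro step a number 29 percentage points lower from compound 1 to compound 3 (beyond the scatter) went the other way. For compound 4 a modest rise is therefore expected, a number 10 percentage points higher from compound 1 to compound 4 (within the scatter). Compound 4 is estimated at 85%, between 55% and 100%.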

Compound 4, a percentage reported as activity, at one concentration (the size of the read-out at that concentration, not a potency): 100%
Compound 4: middle estimate off by 15 percentage points, on the low side, within the range that was stated.
By their numbers in this assay, from the lowest: compound 3; then compound 1; then compounds 2 and 4 (each within the scatter of the next).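

In this assay, bromo in place of hydrogen on an aromatic carbon, ortho to a large group, gives a number 25 percentage points higher from compound 1 to compound 4 (beyond the scatter). This shows that a halogen at this place on the ring can weaken the effect at the concentration tested, so the place tolerates bromo without any gain in effect. Nothing available explains this rise.

Going by these compounds, whether fluoro or chloro at this same place would follow bromo remains open. So does the direction in which an amine or a methoxy group there would move the number.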